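Methyl for Nitro on a Pyrazole Series Against Cathepsin H

A few compounds are considered here, and "the series" means these few. Any claim that something is new, unique, unknown or untested is made for them only; others in the source may bear on it.

Compound 1 `Clc1ccc(C2CC(c3ccccc3)=NN2c2ccccc2)cc1` gives 1170 nM in an assay for inhibition of cathepsin H (Capra hircus), using Lineweaver-Burk analysis; a lower number here means a stronger inhibitor, a higher number a weaker inhibitor; compound 2 `Cc1ccc(C2CC(c3ccccc3)=NN2c2ccccc2)cc1` gives 4180 nM; compound 3 `O=[N+]([O-])c1ccc(-c2cc(-c3ccccc3)nn2-c2ccccc2)cc1` gives 2580 nM.

On these numbers compound 3 lies between the other two: its value sits within the scatter of that of compound 2 and beyond it relative to compound 1. Compound 4 `Cc1ccc(-c2cc(-c3ccccc3)nn2-c2ccccc2)cc1` differs from compound 3 by methyl in place of nitro on an aromatic carbon. For the measured compounds named here, no measured step swaps nitro for methyl; the only step with methyl entering, a 3.6-fold higher number from compound 1 to compound 2 (0.55 log units; beyond the scatter), is modest and upward. By analogy a small rise in this assay is expected, with the step of a 1.4-fold higher number from compound 3 to compound 4 (0.13 log units; within the scatter) seen as likely. Compound 4 is therefore estimated at 3500 nM, in a range from 1200 nM to 10000 nM.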

Compound 4, inhibition constant: 7400 nM
For compound 4 the middle estimate is 2.1-fold (0.33 log units) below the measured one; measured number inside the range.
By their numbers in this assay, from the lowest: compound 1; then compounds 3, 2 and 4 (each within the scatter of the next, the first and the last beyond it).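

In this assay, methyl in place of nitro on this aromatic carbon gives a step beyond the scatter (a 2.9-fold higher number from compound 3 to compound 4 (0.46 log units; beyond the scatter)), so the swap of these two groups at this position now has a measured size. The one earlier step with methyl entering (a 3.6-fold higher number from compound 1 to compound 2 (0.55 log units; beyond the scatter)) replaced chloro on a different core and also went up, so both steps shown point the same way, with no compound against it. Nothing measured here explains either rise.

The compounds shown leave open how an amine or a carboxylic acid on this aromatic carbon would read in this assay, and whether any group there gives a lower number than nitro.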